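Pentyl for chlorophenyl on the carbonyl: cytotoxicity outlook

This account rests on a few compounds, and the source may have more. Where it says the series, first, only, none or still open, it means among the compounds named here.

Of the compounds shown here, three sharing a core have been tested in an ADME assay on L929 cells (Mus musculus) for cytotoxicity, read by resazurin assay, with a stated time of 72 h; on this read-out higher numbers stand for weaker inhibition and lower numbers for stronger inhibition. Compound 1 `OB1OCc2ccc(-n3cc(Sc4ccc(F)cc4)c4ccccc43)cc21` gives > 10 ug/mL in this assay, which is a limit of the assay rather than a number. Compound 2 `CCCNC(=O)c1cccn1-c1ccc2c(c1)B(O)OC2` gives > 10 ug/mL in this assay, again a limit. Compound 3 `O=C(c1cccc(Cl)c1)c1ccn(-c2ccc3c(c2)B(O)OC3)c1` gives > 10 ug/mL in this assay, also a limit. Within the data shown here, compound 3 therefore stands where every value so far stands, because of the limit of > 10 ug/mL in this assay, at which 3 of the 3 values shown sit.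

Compound 4 `CCCCCC(=O)c1ccn(-c2ccc3c(c2)B(O)OC3)c1` has not yet been measured. It differs from compound 3 in one place: pentyl in place of 3-chlorophenyl on a carbonyl carbon. Among the measured compounds shown here, no measured pair differing in a single spot is available, so the size of this step cannot be read from data; the expectation is that the step from compound 3 to compound 4 is a step that the limit leaves unreadable from compound 3 to compound 4, that is, nothing beyond the scatter of this assay. Compound 4 is expected to give roughly 12 ug/mL in this assay, with a range from 6 ug/mL to 30 ug/mL, and most likely again only a limit.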

Compound 4, half-maximal inhibitory concentration: > 10 ug/mL
Compound 4: no number, only a limit; the forecaster's own chance of this, stated with the estimate: 70%; the middle value is on the limit's open side.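

No step can be read from compound 3 to compound 4, because both results are limits of the assay rather than numbers: the limit of > 10 ug/mL in this assay, at which 4 of the 4 values shown sit. The compounds shown leave open whether pentyl in place of 3-chlorophenyl on the carbonyl carbon changes cytotoxicity at all, and where each compound's true value lies.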